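Swapping methoxy for cyano on a pyridine amine

A few compounds are considered here, and "the series" means these few. Any claim that something is new, unique, unknown or untested is made for them only; others in the source may bear on it.

Measured so far:
- compound 1 `FC(F)(F)Oc1ccc(-c2nc3cnc(Nc4ccccn4)cc3[nH]2)cc1`: 62%
- compound 2 `COc1cccc(Nc2cc3[nH]c(-c4cccc(C(F)(F)F)c4)nc3cn2)n1`: 60%
- compound 3 `COc1ccc(Nc2cc3[nH]c(-c4cccc(C(F)(F)F)c4)nc3cn2)nc1`: 33%

All three compounds were tested in an ADME assay on microsomes from liver (Mus musculus) for metabolic stability, read by LC-MS, with a stated time of 30 min, tested at 0.1 uM; on this read-out higher numbers stand for a more stable compound and lower numbers for a less stable compound. Compound 1 gives 62% and compound 2 gives 60% in this assay; these two numbers are within the scatter of each other. Compound 3, with 33% in this assay, has the lowest number of the three, and its gaps to compound 2 and to compound 1 both lie beyond the scatter. Going by the values given here, the only one-point comparison available is a number 27 percentage points lower from compound 2 to compound 3 (beyond the scatter), which shows that moving a methoxy group from one position on the pyridine ring to another was enough to lower the number noticeably.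

The new compound 4 `N#Cc1ccc(Nc2cc3[nH]c(-c4cccc(C(F)(F)F)c4)nc3cn2)nc1` differs from compound 3 in one place: cyano in place of methoxy on an aromatic carbon. No measured pair shows this exchange, and the one shown step concerns a change of position rather than of group, so it gives no direct guide. The expected step of a number 12 percentage points higher from compound 3 to compound 4 (beyond the scatter) is therefore set close to zero, with a broad range to reflect the lack of a matching precedent. For compound 4 in this assay the estimate is 45%, between 25% and 70%.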

Compound 4, percent of the compound remaining: 47%
Compound 4: the middle estimate sits 2 percentage points below what was measured, and the stated range covers the measured number.
By their numbers in this assay, from the lowest: compound 3; then compound 4; then compounds 2 and 1 (each within the scatter of the next).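

Going by these compounds alone, the new step shows that, at this place on the pyridine ring (two atoms from the ring nitrogen, para to a large group), the identity of the group matters, whereas the earlier compounds showed only that moving a methoxy group could change the number. In this assay, cyano in place of methoxy gives a number 14 percentage points higher from compound 3 to compound 4 (beyond the scatter), so this exchange of one small group for another, each counted with the same number of heavy atoms, is enough to move the result beyond the usual scatter. The cyano compound still does not reach the level of the 6-methoxypyridin-2-yl compound, as the comparison gives a number 13 percentage points lower from compound 2 to compound 4 (beyond the scatter), and nothing shown here explains either step.

The compounds shown leave open whether cyano would change the number in the same direction at the ring place occupied by methoxy in compound 2, or with a different group on the other side of the shared core. Going by these compounds, it also remains open how other groups at this place, such as a chlorine atom, a methyl group or a primary amide, would compare with cyano and methoxy.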